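Carbamate nitrogen substituent: compound 3 to compound 4

This account rests on a few compounds, and the source may have more. Where it says the series, first, only, none or still open, it means among the compounds named here.

In a functional assay (Oryctolagus cuniculus) for inhibition of platelet-activating factor receptor (Cavia porcellus) (a lower number here means a stronger inhibitor, a higher number a weaker inhibitor), compound 3 `COc1cc(C(=O)N2CCN(C(=O)c3cc(OC)c(OC)c(OC)c3)C(COC(=O)NC(C)C(C)(C)C)C2)cc(OC)c1OC` gives 170 nM, the lowest of the three numbers recorded. Compound 2 `COc1cc(C(=O)N2CCN(C(=O)c3cc(OC)c(OC)c(OC)c3)C(COC(=O)C3CCCCC3)C2)cc(OC)c1OC` gives 290 nM, and compound 1 `CCCC(=O)OCC1CN(C(=O)c2cc(OC)c(OC)c(OC)c2)CCN1C(=O)c1cc(OC)c(OC)c(OC)c1` gives 420 nM. The step of a 2.5-fold lower number from compound 1 to compound 3 (0.39 log units; beyond the scatter) is beyond the scatter, while a 1.7-fold lower number from compound 2 to compound 3 (0.23 log units; within the scatter) and a 1.4-fold lower number from compound 1 to compound 2 (0.16 log units; within the scatter) are not; compound 3 therefore stands apart from compound 1 only.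

Compound 4 `CCCCCCCCNC(=O)OCC1CN(C(=O)c2cc(OC)c(OC)c(OC)c2)CCN1C(=O)c1cc(OC)c(OC)c(OC)c1` keeps the carbamate of compound 3 and differs in one place: octyl in place of 1,2,2-trimethylpropyl on an amide-type nitrogen. Among the measured compounds shown here, no measured step alters the substituent on this nitrogen; the nearest comparison is the exchange of one carbon chain for another on the carbonyl carbon, a 1.4-fold lower number from compound 1 to compound 2 (0.16 log units; within the scatter), which stayed within the scatter. On that basis a change of the alkyl on the carbamate nitrogen is expected to produce no step beyond the scatter in this assay, and the expected step from compound 3 to compound 4 is a 1.2-fold higher number from compound 3 to compound 4 (0.07 log units; within the scatter). Compound 4 is estimated at 200 nM, within the range 90 nM to 450 nM.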

Compound 4, half-maximal inhibitory concentration: 370 nM
For compound 4 the middle estimate is 1.9-fold (0.27 log units) below the measured one; low and high end bracket the measured number.
By their numbers in this assay, from the lowest: compounds 3, 2, 4 and 1 (each within the scatter of the next, the first and the last beyond it).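

In this assay, the substituent on the carbamate nitrogen now shows an effect on the number: octyl in place of 1,2,2-trimethylpropyl gives a 2.2-fold higher number from compound 3 to compound 4 (0.34 log units; beyond the scatter) and so loses the edge seen with compound 3. The carbamate alone therefore does not set a compound apart from the esters, since a 1.3-fold higher number from compound 2 to compound 4 (0.11 log units; within the scatter) and a 1.1-fold lower number from compound 1 to compound 4 (0.06 log units; within the scatter) both stay within the scatter, and the low number of compound 3 holds only with 1,2,2-trimethylpropyl on that nitrogen among the carbamates shown. No measurement at hand accounts for the difference between these two substituents.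

Octyl and 1,2,2-trimethylpropyl differ in both chain length and branching, and the two compounds cannot separate these. Butyl or hexyl as straight chains, or cyclohexyl, on the same nitrogen would show which of the two tracks with the number.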